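From bromo to trifluoromethyl on the shared core

This account rests on a few compounds, and the source may have more. Where it says the series, first, only, none or still open, it means among the compounds named here.

Compound 1 (`Oc1cc2c(cc1O)C(c1ccco1)NCC2`) and compound 2 (`Oc1cc2c(cc1O)C(c1ccc(Br)cc1)NCC2`) share one core and differ in the ring group attached to it. In an ADME assay on C8166 cells (Homo sapiens) for cytotoxicity, read by MTT assay, with a stated time of 72 h (on this read-out higher numbers stand for lower toxicity in this test and lower numbers for higher toxicity in this test), compound 1 gives > 865000 nM as a limit of the assay. Compound 2 stands at > 625000 nM in the same test, and this too is only a limit. Neither compound therefore has an exact value, and no order between them can be drawn.

Compound 3 (`Oc1cc2c(cc1O)C(c1ccc(C(F)(F)F)cc1)NCC2`) keeps the core of compound 2 but carries trifluoromethyl in place of bromo on an aromatic carbon, para to a large group (trifluoromethyl in place of bromo on an aromatic carbon). Among the measured compounds shown here, no measured step between related compounds is available to size this change. Because compound 2 gives > 625000 nM as a limit, the change in this assay is expected to be none beyond the scatter, and compound 3 may well return only a limit too. The estimated change is a step that the limit leaves unreadable from compound 2 to compound 3 in this reading. The estimate for compound 3 is 640000 nM as the expected value, with an expected range of 250000 nM to 900000 nM around it.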

Compound 3, half-maximal cytotoxic concentration: 42300 nM
Compound 3: the middle estimate sits 15-fold (1.18 log units) above what was measured; the measured number lies below the stated range.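

In this assay, compound 3 is the first of the compounds shown to give an exact value, and it shows that this place on the aromatic ring, para to a large group, is sensitive to the group it carries: trifluoromethyl in place of bromo gives an at least 14-fold lower number from compound 2 to compound 3 (1.16 log units; beyond the scatter). From the compounds shown here alone, on this read-out the lower number stands for higher toxicity in this test, and the true size of the step stays open at its upper end, since compound 2 is held only at a limit: the limit of > 625000 nM in this assay, at which 1 of the 3 values shown sits. Neither group counts any hydrogen-bond donor, hydrogen-bond acceptor or net charge, so a swap that leaves these counts unchanged is still enough to bring the compound from a limit to a measured value.

The compounds shown do not tell whether this step belongs to trifluoromethyl alone or would also appear with another group at the same place, such as a nitrile, a methoxy group or a chlorine atom. They also give no cause for the step, and a second pair differing by the same exchange on another part of the shared core would be needed to tell whether it carries over.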